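Series notes: from compound 3 to compound 4

The source may report more compounds than this note shows. Statements on the series, on what has been measured and on what is new or still open speak of the compounds shown alone.

compound 1 `O=S(=O)(CCO)c1cccc(-c2ccc3nccc(-c4ccncc4)c3n2)c1` gives 59%
compound 2 `CS(=O)(=O)Nc1cccc(-c2ccc3nccc(-c4ccncc4)c3n2)c1` gives 49%
compound 3 `C[C@@H]1CN(S(=O)(=O)c2cccc(-c3ccc4nccc(-c5ccncc5)c4n3)c2)C[C@H](C)N1` gives 36%

In an ADME assay on microsomes from liver (Rattus norvegicus) for metabolic stability, read by LC-MS, using NADPH, with a stated time of 30 min, tested at 0.1 uM (a lower number here means that less of the compound is left, a higher number that more of the compound is left), compound 3 gives 36%, the lowest of the three numbers. Both steps into it are modest: a number 13 percentage points lower from compound 2 to compound 3 (beyond the scatter) and a number 23 percentage points lower from compound 1 to compound 3 (beyond the scatter). The remaining step stays within the scatter: a number 10 percentage points lower from compound 1 to compound 2 (within the scatter).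

The next compound is compound 4 `Nc1cccc(-c2ccc3nccc(-c4ccncc4)c3n2)c1`, and the change is amino in place of (3,5-dimethylpiperazin-1-yl)sulfonyl on an aromatic carbon. In words, this is amino in place of (3,5-dimethylpiperazin-1-yl)sulfonyl on an aromatic carbon.

Among the compounds with values here, no measured step introduces amino, so the evidence is indirect. Read in reverse, the two steps into compound 3 are the only measured cases that lose the 3,5-dimethylpiperazin-1-yl group, and both end on a higher number. The closer guide is compound 2 at 49%, which carries methanesulfonamido on the aromatic carbon in question. A small upward move, no larger than those modest steps, is therefore expected. The expected change is a number 9 percentage points higher from compound 3 to compound 4 (within the scatter). Within the data shown here, with only three measured compounds, the range stays wide. For compound 4 the estimated value is 45%, with an expected range of 27% to 63%.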

Compound 4, percent of the compound remaining: 61%
For compound 4 the middle estimate is 16 percentage points below the measured one; low and high end bracket the measured number.
By their numbers in this assay, from the lowest: compound 3; then compounds 2, 1 and 4 (each within the scatter of the next, the first and the last beyond it).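

In this assay, within the data shown here, the single amino group on this aromatic carbon, meta to a large group, gives a number 25 percentage points higher from compound 3 to compound 4 (beyond the scatter) and shows that the whole (3,5-dimethylpiperazin-1-yl)sulfonyl group, with its 11 heavy atoms and 2 defined stereocentres, can be replaced here without a lower read-out. Taking methylsulfonyl off the nitrogen on the aromatic ring also gives a number 12 percentage points higher from compound 2 to compound 4 (beyond the scatter) while the replacement of (2-hydroxyethyl)sulfonyl gives a number 2 percentage points higher from compound 1 to compound 4 (within the scatter) and so, within these four compounds, a sulfonyl-bearing group at this position is not needed to reach the level of compound 1. Nothing measured here accounts for these steps.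

The compounds shown leave open whether the read-out depends on the free amino nitrogen or only on the loss of the sulfonyl-bearing groups, a question that a hydroxyl or a methoxy on the same carbon would address. Also open is how small groups on that nitrogen, such as methyl or acetyl, would compare, as the one substituent shown there is methylsulfonyl.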